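Compound 4: A Bromine Joins the Hydroxyphenyl Ring

This account rests on a few compounds, and the source may have more. Where it says the series, first, only, none or still open, it means among the compounds named here.

Compound 1, `Fc1ccccc1CSc1nnc(-c2ccncc2)n1-c1ccccc1`, gives > 50000 nM in a functional assay on HepG2 cells (Homo sapiens) for inhibition, read by MTT assay, with a stated time of 48 h (a higher number here means a weaker inhibitor, a lower number a stronger inhibitor), and this is a limit of the assay.
Compound 2, `Clc1ccc(CSc2nnc(-c3ccncc3)n2-c2ccccc2)cc1`, gives 16900 nM in this assay.
Compound 3, `O=C(CSc1nnc(-c2ccncc2)n1-c1ccccc1)N/N=C/c1ccc(O)cc1`, gives > 50000 nM in this assay, and this too is a limit of the assay.

Compound 3 thus sits at the limit of > 50000 nM in this assay, at which 2 of the 3 values shown sit, alongside compound 1, while only compound 2 shows a number. Among the compounds with values here, the single measured step, an at least 2.9-fold lower number from compound 1 to compound 2 (0.47 log units; beyond the scatter), concerns the group on the saturated chain carbon bound to sulfur, a part of the molecule that compound 3 and compound 4 share unchanged.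

Compound 4, `O=C(CSc1nnc(-c2ccncc2)n1-c1ccccc1)N/N=C/c1cc(Br)ccc1O`, differs from compound 3 by 5-bromo-2-hydroxyphenyl in place of 4-hydroxyphenyl on a carbon with a double bond to nitrogen. Within the data shown here, no measured step touches this position, so the expectation rests on compound 3 alone, whose value is a limit. Compound 4 is therefore expected to remain weak, with an estimated step of an at least 1.2-fold lower number from compound 3 to compound 4 (0.09 log units; that floor lies within the scatter). The estimate for compound 4 is 40000 nM, expected to lie between 12000 nM and 150000 nM.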

Compound 4, half-maximal inhibitory concentration: 4390 nM
Beside the measured number, compound 4's estimate is 9.1-fold (0.96 log units) above it; measured number outside the range, below it.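

Within the data shown here, the position on the carbon with a double bond to nitrogen, which no earlier step touched, clearly matters in this assay: 5-bromo-2-hydroxyphenyl in place of 4-hydroxyphenyl gives an at least 11-fold lower number from compound 3 to compound 4 (1.05 log units; beyond the scatter), a large change. On these data alone, the true size of this step remains unknown and could be larger, since compound 3 sits at a limit of the assay: the limit of > 50000 nM in this assay, at which 2 of the 4 values shown sit. Compound 4 also shows that the side chain shared with compound 3 does not by itself hold a compound at that limit.

The change adds a bromine and moves the hydroxyl in one stroke, and the compounds shown do not separate these two parts, since neither plain 2-hydroxyphenyl nor a bromophenyl without the hydroxyl stands among them. As far as these compounds go, whether a chlorine or a methoxy group in place of the bromine, or an amine in place of the hydroxyl, would keep the lower number also stays open.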